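The source may hold more compounds than are shown below. What is called first, only, known or untested is meant among the compounds shown, and "the series" means these compounds.

Of the compounds shown here, three have been measured so far. In a functional assay on SF-295 cells (Homo sapiens) for antiproliferative activity, read by sulforhodamine B assay, with a stated time of 72 h (on this read-out lower numbers stand for stronger inhibition and higher numbers for weaker inhibition), compound 1 `O=C1CS/C(=N/Nc2nncc3ccccc23)N1c1ccccc1` gives 4.6 nM, the lowest of the three numbers. Compound 3 `O=S(=O)(Nc1nccs1)c1ccc(Nc2nncc3ccccc23)cc1` gives 6.5 nM, which lies within the usual scatter of compound 1, so these two cannot be told apart. Compound 2 `S=C(NNc1nncc2ccccc12)Nc1ccccc1` gives 9.5 nM, a higher number than compound 1 and a gap just beyond the scatter.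

The next compound to be tested is compound 4 `O=C1CS/C(=N/Nc2nncc3ccccc23)N1`. It differs from compound 1 in one place, with hydrogen in place of phenyl on an amide-type nitrogen in a ring. Going by the values given here, no two measured compounds differ in only one place, and none shows what a bare hydrogen does at this position, so the size of this step is a matter of judgement. Compound 1, at 4.6 nM, already sits at the low end of the measured numbers, so a change to it seems more likely to raise the number than to lower it. A moderate rise beyond the scatter in this assay is therefore expected, though no change at all cannot be ruled out. The estimate amounts to an expected step of a 4.3-fold higher number from compound 1 to compound 4 (0.64 log units; beyond the scatter). For compound 4 the estimated value is 20 nM, with an expected range from 5 nM to 80 nM.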

Compound 4, half-maximal inhibitory concentration: 2.4 nM
Compound 4: the middle estimate sits 8.3-fold (0.92 log units) above what was measured, and the stated range ends above it.
By their numbers in this assay, from the lowest: compounds 4, 1, 3 and 2 (each within the scatter of the next, the first and the last beyond it).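

In this assay, replacing the phenyl on the amide-type nitrogen in the ring with hydrogen gives a 1.9-fold lower number from compound 1 to compound 4 (0.28 log units; within the scatter), so compound 1 and compound 4 cannot be told apart on this read-out. This pair gives the first direct view of this position: a phenyl of 6 heavy atoms can be removed without moving the number beyond the usual scatter, so, in this pair, a low number does not depend on that ring. No supporting data are available to explain why the two compounds read alike.

From the compounds shown here alone, the pair covers only phenyl and hydrogen, so it remains open how this nitrogen would respond to a small methyl, a longer chain such as butyl, or a chain ending in an amine or a carboxylic acid. A single pair in one cell line also leaves open whether the same replacement would give a similar result in other cells or on a different core.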